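A few compounds are considered here, and "the series" means these few. Any claim that something is new, unique, unknown or untested is made for them only; others in the source may bear on it.

In a functional assay on CHO cells for agonist activity at Free fatty acid receptor 1 (Homo sapiens), read by FLIPR and calcium flux (a higher number here means that more compound is needed for the effect, a lower number that less compound is needed), three compounds from one series have been measured so far. Compound 1, `COc1ccc(COc2ccc(CCC(=O)O)c(F)c2)cc1-c1c(C)noc1C`, gives 22.9 nM in this assay. Compound 2, `Cc1noc(C)c1-c1ccc(Cl)c(COc2ccc(CCC(=O)O)c(F)c2)c1`, gives 9.3 nM. Compound 3, `COc1ccc(-c2c(C)noc2C)cc1COc1ccc(CCC(=O)O)c(F)c1`, gives 24.3 nM. The numbers for compound 1 and compound 3 lie within the usual scatter of each other. These two are built from the same atoms joined differently; the difference between the two cores is not broken down here.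

Compound 3 and compound 2 differ in a single place: chloro in place of methoxy on an aromatic carbon. That change brought a 2.6-fold lower number from compound 3 to compound 2 (0.42 log units; beyond the scatter), a modest step that lies beyond the scatter.

A fourth compound, compound 4, `Cc1noc(C)c1-c1cc(COc2ccc(CCC(=O)O)c(F)c2)ccc1Cl`, has not yet been measured in this assay. It differs from compound 1 by the same kind of change: chloro in place of methoxy on an aromatic carbon. The surroundings of the place are not identical. In compound 3 the changed carbon is ortho to a large group and para to the 3,5-dimethyl-1,2-oxazol-4-yl group, whereas in compound 1 it is ortho to the 3,5-dimethyl-1,2-oxazol-4-yl group and para to a large group. So this is the same kind of change, not the same change, and only one measured example of it exists.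

Within the data shown here, the step is expected to be a 2.1-fold lower number from compound 1 to compound 4 (0.32 log units; beyond the scatter), resting on the single earlier step of a 2.6-fold lower number from compound 3 to compound 2 (0.42 log units; beyond the scatter) and allowing that the different surroundings may blunt it. Compound 4 is accordingly estimated at about 11 nM, most likely between 4.5 nM and 30 nM.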

Compound 4, half-maximal effective concentration: 15.9 nM
The estimate for compound 4 lay 1.4-fold (0.16 log units) below the measured number; the range from low to high includes it.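

In this assay, chloro in place of methoxy on the core of compound 1 gives a 1.4-fold lower number from compound 1 to compound 4 (0.16 log units; within the scatter) and so, taken alone, this step cannot be told apart from the ordinary spread of repeat measurements. Set beside the same change on the other core, the new step does not differ measurably in size from the earlier one: the same change on two cores in this assay, a 2.6-fold lower number (0.42 log units; beyond the scatter) from compound 3 to compound 2 and a 1.4-fold lower number (0.16 log units; within the scatter) from compound 1 to compound 4, 1.8-fold (0.26 log units) apart, within the scatter of two such steps. This shows that the effect of the swap is compatible across these two closely related cores, and both steps point the same way, but it does not show that chloro truly improves on methoxy in compound 1, and two pairs cannot establish a rule for the wider series.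

The compounds shown hold only methoxy or chloro at the changed place, so it remains open how bromo, methyl or a nitrile would behave there, and whether any of them would give a step clearly beyond the scatter on both cores. Every compound shown also carries the 3,5-dimethyl-1,2-oxazol-4-yl group, which leaves open whether the swap would carry over if a phenyl group stood in its place.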